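Working notes: triazole N-substituent changes in the quinoline series

A few compounds are considered here, and "the series" means these few. Any claim that something is new, unique, unknown or untested is made for them only; others in the source may bear on it.

Measured so far:
compound 1 `CN(CCNCc1cn(Cc2ccc(Br)cc2)nn1)CCNc1ccnc2cc(Cl)ccc12` — 9300 nM
compound 2 `CN(CCNCc1cn(Cc2nc3ccccc3[nH]2)nn1)CCNc1ccnc2cc(Cl)ccc12` — 164000 nM

Both compounds were tested in a functional assay on HCC827 cells (Homo sapiens) for antiproliferative activity, read by sulforhodamine B assay, with a stated time of 72 h; a higher number here means a weaker inhibitor, a lower number a stronger inhibitor. Compound 2 stands at the highest of the two numbers; its nearest neighbour is compound 1, and the step of an 18-fold higher number from compound 1 to compound 2 (1.25 log units; beyond the scatter) is large, well beyond the scatter. So the only measured step in the series shows that what sits on the saturated chain carbon bound to the aromatic nitrogen of the triazole can move the number a long way.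

Compound 3 `CN(CCNCc1cn(CCCn2nn[nH]c2=O)nn1)CCNc1ccnc2cc(Cl)ccc12` is not yet measured. Relative to compound 2 the change is a group of 8 heavy atoms (3 carbon, 4 nitrogen, 1 oxygen; one five-membered aromatic ring with 4 hetero atoms) in place of a group of 9 heavy atoms (7 carbon, 2 nitrogen; one five-membered aromatic ring with 2 hetero atoms, one six-membered aromatic ring of carbon only), on a saturated chain carbon bound to an aromatic nitrogen. Among the measured compounds shown here, no measured pair covers this exchange, so the direction cannot be read from the data; the step from compound 1 to compound 2 bears on it only by showing that this position is sensitive. With compound 2 already at the high end, some regression toward the middle of the two numbers is expected, but with wide uncertainty. For compound 3 the expected step is a 2.3-fold lower number from compound 2 to compound 3 (0.37 log units; beyond the scatter), giving an estimate of 70000 nM with a range from 15000 nM to 300000 nM.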

Compound 3, half-maximal inhibitory concentration: > 200000 nM
Compound 3: no number, only a limit; the forecaster's own chance of this, stated with the estimate: 15%; at least 2.8-fold (0.45 log units) between middle value and limit.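

In this assay compound 3 gives > 200000 nM, which is a limit of the assay and not a number. Set against the 4-bromophenyl group, the entering group gives an at least 21-fold higher number from compound 1 to compound 3 (1.33 log units; beyond the scatter), so the large move away from the 4-bromophenyl group is no longer tied to the 1H-benzimidazol-2-yl group alone, and it now also holds for a group with a five-membered aromatic ring with 4 hetero atoms and no six-membered aromatic ring of carbon only. Against 1H-benzimidazol-2-yl the exchange reads an at least 1.2-fold higher number from compound 2 to compound 3 (0.08 log units; that floor lies within the scatter), which sets no order between these two groups at this saturated chain carbon bound to an aromatic nitrogen: the limit of > 200000 nM in this assay, at which 1 of the 3 values shown sits.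

Going by these compounds, whether the low number of the series depends on the bromine or on the six-membered aromatic ring of carbon only stays open, and an unsubstituted phenyl or a 4-chlorophenyl group would separate the two. On these data alone, how a terminal amine or a carboxylic acid on this chain would compare with the 4-bromophenyl group also remains unknown.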